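The source may report more compounds than this note shows. Statements on the series, on what has been measured and on what is new or still open speak of the compounds shown alone.

Values in an ADME assay on BCBL1 cells (Homo sapiens) for cytotoxicity, with a stated time of 7 days; on this read-out higher numbers stand for lower toxicity in this test and lower numbers for higher toxicity in this test:
compound 1 (`C=CCOc1nc(N)nc2c1ncn2/C=C1/CC1(CO)CO`) : > 20000 nM (a limit of the assay)
compound 2 (`CCOc1nc(N)nc2c1ncn2/C=C1/CC1(CO)CO`) : > 20000 nM (a limit of the assay)
compound 3 (`Nc1nc(NCc2ccccc2)c2ncn(/C=C3/CC3(CO)CO)c2n1`) : 19900 nM

Among the measured compounds shown here, compound 3 holds the only actual number in this short series. Compound 1 and compound 2 stand at the limit of > 20000 nM in this assay, at which 2 of the 3 values shown sit.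

The change to compound 4 (`Nc1nc(NC2CC2)c2ncn(/C=C3/CC3(CO)CO)c2n1`) is cyclopropyl in place of benzyl on a nitrogen on an aromatic ring. For the measured compounds named here, no measured step alters the group on this nitrogen. The nearest evidence is a number no higher from compound 1 to compound 3 (the limit leaves the size open) and a number no higher from compound 2 to compound 3 (the limit leaves the size open), and neither has a readable size. The remaining step, a step that the two limits leave unreadable from compound 1 to compound 2, is equally unreadable and concerns a different group.

With compound 3 at 19900 nM as the sole numerical anchor, no step beyond the usual scatter is expected in this assay. For compound 4, this assay may report only a limit. The expected change is a 1.0-fold higher number from compound 3 to compound 4 (0.00 log units; within the scatter). For compound 4 the estimated value is 20000 nM, with an expected range of 10000 nM to 40000 nM.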

Compound 4, half-maximal cytotoxic concentration: 71500 nM
Compound 4: the middle estimate sits 3.6-fold (0.55 log units) below what was measured; measured number outside the range, above it.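

In this assay, the group on a nitrogen on an aromatic ring now has a readable effect: cyclopropyl in place of benzyl gives a 3.6-fold higher number from compound 3 to compound 4 (0.56 log units; beyond the scatter). On this one pair, the read-out responds to the group on this nitrogen, and the cyclopropyl compound, with 3 heavy atoms in that group against 7, shows the lower toxicity in this test. The steps from compound 1 and from compound 2 to compound 4 cannot be read, because the values of compound 1 and compound 2 are limits: the limit of > 20000 nM in this assay, at which 2 of the 4 values shown sit.

A single pair cannot tell whether the higher number follows the smaller group or the loss of the six-membered aromatic ring. Cyclohexyl on this nitrogen would separate those two readings, and a plain methyl there would show how far the trend in size extends.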